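The compounds below may be only part of what the source reports. "The series", "measured", "known", "first", "only" and "open" are said of these compounds alone.

Working notes on the series, read in a functional assay on PC-3 cells (Homo sapiens) for inhibition, read by sulforhodamine B assay, with a stated time of 48 h; a higher number here means a weaker inhibitor of growth, a lower number a stronger inhibitor of growth. Compound 1 `S=C(N/N=C/c1cccs1)Nc1ccccc1` is the reference, and in this assay compound 1 gives > 100000 nM, which is a limit and not a number. Compound 2 `S=C(N/N=C/c1cccs1)Nc1cccc2ccccc12` gives > 100000 nM, also a limit. Compound 3 `C=CCNC(=S)N/N=C/c1cccs1` gives > 100000 nM, again a limit. Compound 1 therefore has no number of its own and shares its standing with the other two: the limit of > 100000 nM in this assay, at which 3 of the 3 values shown sit. Within the data shown here, no measured step exists yet.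

Compound 4 `S=C(N/N=C/c1cccs1)Nc1ccc(Br)cc1` keeps the core of compound 1 and changes in one place: bromo in place of hydrogen on an aromatic carbon, para to a large group. Among the measured compounds shown here, with no measured step to size this change, only a small move is expected. The estimated step of an at least 1.6-fold lower number from compound 1 to compound 4 (0.22 log units; that floor lies within the scatter) is expected to run, if it shows at all, toward stronger inhibition of growth. Compound 4 is estimated at 60000 nM, with an expected range of 20000 nM to 100000 nM. A result reported only as a limit remains a real possibility.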

Compound 4, concentration for 50% growth inhibition: 79400 nM
Beside the measured number, compound 4's estimate is 1.3-fold (0.12 log units) below it; the measured number falls inside the stated range.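

In this assay, among these compounds, compound 4 gives 79400 nM, the first reading that is a number and not a limit, with the bromo on an aromatic carbon, para to a large group. The step is an at least 1.2-fold lower number from compound 1 to compound 4 (0.10 log units; that floor lies within the scatter); it is only a floor, since compound 1 has a limit and no number of its own, so the true size of the change cannot be read from this pair. The other compounds shown offer no number for comparison: the limit of > 100000 nM in this assay, at which 3 of the 4 values shown sit.

The compounds shown leave open whether a chloro, a methoxy or an amine in the same place would also give a number. They also leave open whether the bromo would read the same at another place on this ring.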